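The compounds below may be only part of what the source reports. "The series", "measured", "known", "first", "only" and "open" are said of these compounds alone.

Compound 3 `CCC(=O)N1N=C(c2ccc(F)cc2)CC1c1cn(-c2ccccc2)nc1-c1ccc(Cl)c(Cl)c1` and compound 4 `CC(=O)N1N=C(c2ccc(F)cc2)CC1c1cn(-c2ccccc2)nc1-c1ccc(Cl)c(Cl)c1` share a core that differs from that of compound 1 `CCC(=O)N1N=C(c2ccc(C)cc2)CC1c1cn(-c2ccccc2)nc1-c1ccc(Cl)c(Cl)c1` and compound 2 `CC(=O)N1N=C(c2ccc(C)cc2)CC1c1cn(-c2ccccc2)nc1-c1ccc(Cl)c(Cl)c1` by fluoro in place of methyl on an aromatic carbon. In a functional assay on the whole organism (strain Wistar) for inhibition, with Rattus norvegicus as the target, read by paw edema, with a stated time of 30 min, at a dose of 50 mg/kg by the oral route (on this read-out higher numbers stand for more inhibition at the one dose given (going by the name of the read-out) and lower numbers for less inhibition), compound 1 gives 29.8%, compound 2 gives 27.7% and compound 3 gives 51.1%. The step of a number 21.3 percentage points higher from compound 1 to compound 3 (beyond the scatter) is the only one of the three that is beyond the scatter, so on this read-out compound 3 stands apart from both others. The change from compound 1 to compound 2 is hydrogen in place of methyl on a saturated chain carbon bound to a carbonyl carbon, and it made the step of a number 2.1 percentage points lower from compound 1 to compound 2 (within the scatter), which is within the scatter. The change from compound 3 to compound 4 is hydrogen in place of methyl on a saturated chain carbon bound to a carbonyl carbon, the same change at the same place on the other core. Because the step of a number 2.1 percentage points lower from compound 1 to compound 2 (within the scatter) was within the scatter, compound 4 is expected to stay close to compound 3, with a step of about a number 2.1 percentage points lower from compound 3 to compound 4 (within the scatter) in this assay. Compound 4 is therefore estimated at 49% in this assay, with a likely range from 38% to 60%.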

Compound 4, a percentage reported as inhibition, in the whole organism at one dose (the size of the read-out at that dose, not a potency): 45.7%
The estimate for compound 4 lay 3.3 percentage points above the measured number; measured number inside the range.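

In this assay, hydrogen in place of methyl on a saturated chain carbon bound to a carbonyl carbon gave a number 5.4 percentage points lower from compound 3 to compound 4 (within the scatter), and this step matches the one on the other core: the same change on two cores in this assay, a number 2.1 percentage points lower (within the scatter) from compound 1 to compound 2 and a number 5.4 percentage points lower (within the scatter) from compound 3 to compound 4, 3.3 percentage points apart, within the scatter of two such steps

Fluoro in place of methyl on an aromatic carbon gave a number 18 percentage points higher from compound 2 to compound 4 (beyond the scatter), so this change also carried over, here between the propanoyl and acetyl compounds: the same change on two cores in this assay, a number 21.3 percentage points higher (beyond the scatter) from compound 1 to compound 3 and a number 18 percentage points higher (beyond the scatter) from compound 2 to compound 4, 3.3 percentage points apart, within the scatter of two such steps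

This shows that, among these four compounds, each change had much the same size on both cores, but it rests on one pair of steps per change at a single oral dose and does not show that either change would carry over to any other core or dose.

The compounds shown leave open how a longer chain, such as butanoyl, or a chain ending in an amine would read in place of propanoyl or acetyl. They also leave open whether chloro, methoxy or trifluoromethyl on the aromatic carbon that carries fluoro would give a number like those of compound 3 and compound 4.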